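A Methyl Added Where the Best Number Stands

The source may report more compounds than this note shows. Statements on the series, on what has been measured and on what is new or still open speak of the compounds shown alone.

compound 1 `Cc1cc(OCc2ccccc2)c2nc(C)c(C)n2c1` 71%
compound 2 `Cc1nc2c(OCc3ccccc3)cccn2c1N` 96%
compound 3 `Cc1nc2c(OCc3ccc(C(F)(F)F)cc3)cccn2c1N` 8%

In a functional assay on the whole organism with Canis familiaris (Canis lupus familiaris) as the target, at a dose of 8 mg/kg by the oral route (on this read-out lower numbers stand for a weaker effect and higher numbers for a stronger effect at the one dose given), compound 2 gives the highest of the three numbers; compound 1 lies lower by more than the scatter, and compound 3 lower still. Among the compounds with values here, the only measured step from compound 2 is a number 88 percentage points lower from compound 2 to compound 3 (beyond the scatter), a trifluoromethyl in place of hydrogen on an aromatic carbon, which is a different change from the one considered here. Compound 4 `Cc1cc(OCc2ccccc2)c2nc(C)c(N)n2c1` differs from compound 2 by methyl in place of hydrogen on an aromatic carbon. Compound 1 carries a methyl at that place but differs from compound 2 in more than one spot, so its lower number cannot be assigned to the methyl alone. Within the data shown here, no measured step bears directly on this change. Compound 4 is therefore expected to remain close to compound 2, with a number 11 percentage points lower from compound 2 to compound 4 (beyond the scatter) likely within or just beyond the scatter. Compound 4 is estimated at 85%, between 55% and 99%.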

Compound 4, a percentage reported as inhibition, in the whole organism at one dose (the size of the read-out at that dose, not a potency): 50%
Compound 4: the middle estimate sits 35 percentage points above what was measured; measured number below the stated range.
By their numbers in this assay, from the lowest: compound 3; then compound 4; then compound 1; then compound 2.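

In this assay, a single methyl on the six-membered aromatic ring, two atoms from the ring nitrogen, is far from a neutral addition: the change gives a number 46 percentage points lower from compound 2 to compound 4 (beyond the scatter), a large step for one carbon. With this methyl present, the other changed site matters too, since amino in place of methyl gives a number 21 percentage points lower from compound 1 to compound 4 (beyond the scatter), a modest step. Nothing at hand explains either drop.

From the compounds shown here alone, whether an ethyl group or a chlorine atom at this place would fare like methyl remains open. So does whether methyl would have the same effect alongside the trifluoromethyl of compound 3.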